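The compounds below may be only part of what the source reports. "The series", "measured", "known", "first", "only" and "open" are said of these compounds alone.

Of the compounds shown here, three of one series have been measured in a physicochemical assay for solubility, with a stated time of 18 h, at pH 7.4; on this read-out lower numbers stand for lower solubility and higher numbers for higher solubility. Compound 1 `COc1ccc(Oc2ccc3c(NCCCNCc4cccc(OC)c4O)ccnc3c2)cc1` gives 14500 nM in this assay. Compound 3 `COc1ccc(Oc2ccc3c(NCCCNCc4ccco4)ccnc3c2)cc1` differs from compound 1 only in the group on the amine-bearing chain, (furan-2-yl in place of 2-hydroxy-3-methoxyphenyl on a saturated chain carbon bound to an amine nitrogen), and in this assay compound 3 gives 14500 nM; the two stand level, as no change at the digits printed from compound 1 to compound 3 (within the scatter) shows, together the highest of the three numbers. Compound 2 `COc1cccc(CNCCCNc2ccnc3cc(Cc4ccc(C#N)cc4)ccc23)c1O` carries a different change on the core, (4-cyanobenzyl in place of 4-methoxyphenoxy on an aromatic carbon), and in this assay compound 2 gives 4200 nM; this change brought a 3.5-fold lower number from compound 1 to compound 2 (0.54 log units; beyond the scatter), a modest step that is nonetheless clear of the scatter.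

Compound 4 `N#Cc1ccc(Cc2ccc3c(NCCCNCc4ccco4)ccnc3c2)cc1` has not yet been measured. It arises from compound 3 by the same change that turned compound 1 into compound 2, (4-cyanobenzyl in place of 4-methoxyphenoxy on an aromatic carbon), at a place described in the same words, so the two pairs differ only in the chain group that sets compound 3 apart from compound 1. The expectation for compound 4 rests on the earlier step of a 3.5-fold lower number from compound 1 to compound 2 (0.54 log units; beyond the scatter) and on compound 3 standing level with compound 1, as no change at the digits printed from compound 1 to compound 3 (within the scatter) shows, which gives no reason to think the change would act differently on this core. Compound 4 is therefore expected to move by about a 3.5-fold lower number from compound 3 to compound 4 (0.54 log units; beyond the scatter) in this assay. Compound 4 is estimated to give roughly 4200 nM, most likely between 1800 nM and 9500 nM.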

Compound 4, solubility: 4200 nM
Beside the measured number, compound 4's estimate shows no gap at the digits printed, and the stated range covers the measured number.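

In this assay the exchange of 4-methoxyphenoxy for 4-cyanobenzyl carries over cleanly: the new pair shows a 3.5-fold lower number from compound 3 to compound 4 (0.54 log units; beyond the scatter), the same size at the digits printed as the earlier 3.5-fold lower number from compound 1 to compound 2 (0.54 log units; beyond the scatter), and the two 4-cyanobenzyl compounds stand level, with no change at the digits printed from compound 2 to compound 4 (within the scatter). This shows the change giving one and the same step with two different chain groups, 2-hydroxy-3-methoxyphenyl and furan-2-yl, but it rests on only these two matched pairs, both with the change at the same place on the shared core, so it does not establish a general rule for the series or show how the change would behave with any other chain group. Nothing given here bears on why the step has this size, so the result stands as an observation without an explanation.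

The compounds shown leave open whether the step would keep its size if a carboxylic acid or a simple amine stood in place of furan-2-yl at the end of the chain. They also leave open whether a longer chain linking the two nitrogens would alter the step, and whether the two chain groups would still stand level there.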